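The compounds below may be only part of what the source reports. "The series", "measured", "known", "first", "only" and "open" are said of these compounds alone.

For the measured compounds named here, compound 1 `CC1(c2ccccc2)CC(=O)N(CC(=O)N2CCN(c3ccccc3)CC2)C1=O` is the one member of this small set that gives a number in a functional assay on the whole organism (strain CD-1) with Mus musculus as the target, with a stated time of 0.5 h; a higher number here means that more compound is needed for the effect, a lower number that less compound is needed: compound 1 gives 100 mg/kg. Compound 2 `CC1(c2ccccc2)CC(=O)N(CC(=O)N2CCN(c3ccccc3Cl)CC2)C1=O` gives "not active" (no number reported) in this assay, with no number reported for it. Compound 3 `CC1(c2ccccc2)CC(=O)N(CC(=O)N2CCN(c3ccc(F)cc3)CC2)C1=O` likewise gives "not active" (no number reported) in this assay, again with no number reported for it. Compound 3 therefore stands without a numerical reading, and the pair of compound 2 and compound 3 offers no second number either; only compound 1 sets a scale.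

Compound 4 `CC1(c2ccccc2)CC(=O)N(CC(=O)N2CCN(c3ncccn3)CC2)C1=O` has not yet been measured in this assay. It differs from compound 3 in one place: pyrimidin-2-yl in place of 4-fluorophenyl on an amine nitrogen in a ring. Going by the values given here, since compound 3 has no number, no step from it to compound 4 can be stated, and no pair of measured compounds shows a step of this kind at all. What the set does show is that compound 1 reaches a reading while compound 2 and compound 3 do not, so the expectation for compound 4 has to be wide, with a real chance that this assay again reports no number. Compound 4 is estimated to give 100 mg/kg in this assay, within a range from 30 mg/kg to 300 mg/kg.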

Compound 4, minimum effective dose: "not active" (no number reported)
Nothing numeric was reported for compound 4; the estimate stays without a comparison.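

For the compounds shown here, compound 3 and compound 4 both stand without a number in this assay, so no step between them can be read. No measured evidence bears on this result. The compounds shown leave open how much the group on the amine nitrogen in the ring matters, since only compound 1 gives a number.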